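The compounds below may be only part of what the source reports. "The series", "measured", "known", "first", "only" and "open" are said of these compounds alone.

Of the compounds shown here, three have so far been tested in a functional assay on MIA PaCa-2 cells (Homo sapiens) for inhibition, read by MTT assay, with a stated time of 72 h; on this read-out higher numbers stand for weaker inhibition and lower numbers for stronger inhibition. Compound 1 `Cc1cnc(C(=O)Nc2ccc3ncccc3c2)cn1` gives in this assay only a limit, > 10000 nM, and not a number. Compound 2 `Cc1cnc(C(=O)Nc2cccc3ccc(C)nc23)cn1` likewise gives in this assay only a limit, > 10000 nM. Among the measured compounds shown here, compound 3 `Cc1cnc(C(=O)Nc2cc(F)cc3cccnc23)cn1` is the one with a real reading: in this assay compound 3 gives 310 nM, the only number among the three values shown. The other two values are the limit of > 10000 nM in this assay, at which 2 of the 3 values shown sit, so compound 3 stands alone as the single point against which anything new can be judged.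

Compound 4 `Cc1cnc(C(=O)Nc2cc(Cl)cc3cccnc23)cn1` has not yet been measured. It differs from compound 3 by chloro in place of fluoro on an aromatic carbon. No two measured compounds here differ by such a swap, so the size of this kind of step is not shown by any measured pair. With so little to go on, the step from compound 3 to compound 4 is expected to be small, not beyond the usual scatter in this assay, a 1.2-fold lower number from compound 3 to compound 4 (0.09 log units; within the scatter). Compound 4 is therefore estimated at 250 nM, with a likely range from 80 nM to 800 nM.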

Compound 4, half-maximal inhibitory concentration: 1500 nM
Compound 4: middle estimate off by 6.0-fold (0.78 log units), on the low side, outside the stated range (above it).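

In this assay, this position proves sensitive to which halogen it carries, with a 4.8-fold higher number from compound 3 to compound 4 (0.68 log units; beyond the scatter). This step lies beyond the usual scatter, even though fluoro and chloro are each a single heavy atom, with no hydrogen-bond donors or acceptors and no net charge, so one atom exchanged at this place on the aromatic ring is enough to shift the reading. Of the two halogens, fluoro gives the lower number and so the stronger inhibition, yet compound 4 still gives a real number and not a limit, which makes this a modest loss and not a complete one.

Whether the reading would keep rising or would fall again with bromo, methoxy or an amine at this place remains open, and so does the reason for the step, since no property of either group is measured here. Numbers are also too few to support any wider pattern across the core: the limit of > 10000 nM in this assay, at which 2 of the 4 values shown sit.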